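Removing the chloro from compound 2

A few compounds are considered here, and "the series" means these few. Any claim that something is new, unique, unknown or untested is made for them only; others in the source may bear on it.

Compound 1 `COc1ccc(CSc2nnc([C@@H](C)c3ccc4cc(OC)ccc4c3)n2-c2ccc(Cl)cc2)cc1`: <= 400000 nM (a limit, not a number)
Compound 2 `COc1ccc2cc([C@H](C)c3nnc(SCc4ccc(Cl)cc4)n3-c3ccc(Cl)cc3)ccc2c1`: 5800 nM

Both compounds were tested in a functional assay on PC-3 cells (Homo sapiens) for cytotoxicity, read by MTT assay; on this read-out higher numbers stand for weaker inhibition and lower numbers for stronger inhibition. For the measured compounds named here, there, compound 2 stands at 5800 nM, the only true number in this small set, so it cannot yet be ranked against a measured neighbour. Compound 1 gives only (the limit of <= 400000 nM in this assay, at which 1 of the 2 values shown sits).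

Compound 3 `COc1ccc2cc([C@H](C)c3nnc(SCc4ccccc4)n3-c3ccc(Cl)cc3)ccc2c1` departs from compound 2 by a single change, (hydrogen in place of chloro on an aromatic carbon), with hydrogen in place of chloro on an aromatic carbon. The same difference can be read as 4-chlorobenzyl to benzyl. Going by the values given here, one measured step touches this group, a step that the limit leaves unreadable from compound 1 to compound 2, where chloro replaces methoxy. That step offers no size to carry over, and it gives no direction either. No step beyond the usual scatter can therefore be argued for in this assay, and the expectation stays anchored on compound 2 at 5800 nM. The expected move is a 1.2-fold higher number from compound 2 to compound 3 (0.08 log units; within the scatter). For compound 3 the estimated value is 7000 nM, with an expected range of 2000 nM to 25000 nM.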

Compound 3, half-maximal inhibitory concentration: 14200 nM
Estimate against measurement, compound 3: 2.0-fold (0.31 log units) below; the range from low to high includes it.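

In this assay, the chloro on the benzyl group now has a size that can be read: replacing it with hydrogen gives a 2.4-fold higher number from compound 2 to compound 3 (0.39 log units; beyond the scatter). This modest step favours the 4-chlorobenzyl group of compound 2 over the benzyl group of compound 3, yet compound 3 still gives a true number, so this pair shows that the chloro at this place is not needed for a measurable reading. Compound 1 carries only a limit, not a number, so the steps from it to compound 2 and to compound 3 cannot be read: the limit of <= 400000 nM in this assay, at which 1 of the 3 values shown sits.

On these data alone, whether the lower number belongs to chloro in particular remains open, since a single pair cannot separate it from what fluoro, bromo, trifluoromethyl or an amine would give on this aromatic carbon, and methoxy offers no readable comparison. Also open, as far as these compounds go, is whether the step would keep its size if the 4-chlorophenyl group shared by all three compounds were changed, as this one pair covers only a single setting of the shared core.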